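This account rests on a few compounds, and the source may have more. Where it says the series, first, only, none or still open, it means among the compounds named here.

Going by the values given here, compound 2 `CC(C)OC(=O)N1CCC(O[C@H]2CC[C@H](Oc3cnc(S(C)(=O)=O)cn3)CC2)CC1` is one of two compounds measured in a functional assay on isolated protein for agonist activity at Glucose-dependent insulinotropic receptor (Rattus norvegicus), read by HTRF and cAMP accumulation (a higher number here means a larger maximal response, a lower number a smaller maximal response), where compound 2 gives 120%. Compound 1 `Cc1nc(O[C@H]2CC[C@H](OC3CCN(C(=O)OC(C)(C)C)CC3)CC2)ccc1C(=O)N(C)C` gives 111% in this assay, and the gap between the two values lies within the usual scatter. Compound 3 `CS(=O)(=O)c1cnc(O[C@H]2CC[C@H](OC3CCN(CC4(C(F)(F)F)CCC4)CC3)CC2)cn1` has not yet been measured. It differs from compound 2 in one place: (1-(trifluoromethyl)cyclobutyl)methyl in place of isopropoxycarbonyl on an amine nitrogen in a ring. Among the compounds with values here, no step between measured compounds covers this kind of change, so the expected step from compound 2 to compound 3, a number 15 percentage points lower from compound 2 to compound 3 (beyond the scatter), is taken as none beyond the scatter. Compound 3 is therefore estimated at 105%, with a range from 80% to 125%.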

Compound 3, largest response reached (Emax), in percent of the reference or control that the assay uses: 99%
Estimate against measurement, compound 3: 6 percentage points above; measured number inside the range.
By their numbers in this assay, from the lowest: compound 3; then compounds 1 and 2 (each within the scatter of the next).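

In this assay, going by these compounds alone, the step at this amine nitrogen in a ring, (1-(trifluoromethyl)cyclobutyl)methyl in place of isopropoxycarbonyl, is a number 21 percentage points lower from compound 2 to compound 3 (beyond the scatter), the first change at this position to be read. The entering group has no carbonyl, and compound 3 still gives 99%, so a carbonyl on this nitrogen is not required for a response of this size. Nothing shown accounts for the size of the step. The compounds shown leave open whether the trifluoromethyl or the four-membered ring goes with the step, which a plain cyclobutylmethyl group on the same nitrogen would separate.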